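Cyclopropyl for cyclopentyl on the amide of compound 2

This account rests on a few compounds, and the source may have more. Where it says the series, first, only, none or still open, it means among the compounds named here.

Two compounds sharing a phthalazinone core bearing a benzylic amide have been tested in a functional assay on A549 cells (Homo sapiens) for antiproliferative activity, read by MTT assay, with a stated time of 72 h; a higher number here means a weaker inhibitor, a lower number a stronger inhibitor. Compound 1 `Cc1noc(C)c1-c1nn(Cc2ccc(C(=O)NC3CC3)cc2)c(=O)c2ccccc12` reaches only the assay limit, giving > 100000 nM, which is a limit rather than a number. Among the measured compounds shown here, compound 2 `Cn1cc(-c2nn(Cc3ccc(C(=O)NC4CCCC4)cc3)c(=O)c3ccccc23)cn1` gives 32300 nM in this assay, the only measured number in the set. The value of compound 1 is the one that sits at the limit (the limit of > 100000 nM in this assay, at which 1 of the 2 values shown sits).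

Compound 3 `Cn1cc(-c2nn(Cc3ccc(C(=O)NC4CC4)cc3)c(=O)c3ccccc23)cn1` has not yet been measured. It differs from compound 2 in one place: cyclopropyl in place of cyclopentyl on an amide-type nitrogen whose other neighbour is the carbonyl carbon. For the measured compounds named here, no measured pair shows this change on the shared core, so the direction of the step is not fixed by the data. Given that the one compound carrying a cyclopropylcarbamoyl group, compound 1, gives > 100000 nM, a modest weakening is expected, with an estimated step of a 1.7-fold higher number from compound 2 to compound 3 (0.23 log units; within the scatter) from compound 2 to compound 3. Compound 3 is therefore expected to give about 55000 nM, within a range from 15000 nM to 200000 nM, with a real chance that only a limit is reported.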

Compound 3, half-maximal inhibitory concentration: 51200 nM
Compound 3: the middle estimate sits 1.1-fold (0.03 log units) above what was measured; the range from low to high includes it.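

In this assay, cyclopropyl in place of cyclopentyl on an amide-type nitrogen gives a 1.6-fold higher number from compound 2 to compound 3 (0.20 log units; within the scatter), so this first comparison at the position, with nothing else changed, does not separate the two rings. The cyclopropylcarbamoyl group therefore no longer appears only in a compound at the limit, since compound 3 carrying it gives a measured number. The change on the aromatic carbon, 1-methyl-1H-pyrazol-4-yl in place of 3,5-dimethyl-1,2-oxazol-4-yl, gives an at least 1.9-fold lower number from compound 1 to compound 3 (0.29 log units; that floor lies within the scatter), which is only a floor, and the true size of this step stays unknown, as the value of compound 1 is a limit and not a number: the limit of > 100000 nM in this assay, at which 1 of the 3 values shown sits.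

The compounds shown leave open whether any group on the amide nitrogen can move the number beyond the scatter, for example a longer chain, a chain ending in an amine or a carboxylic acid, or a phenyl ring. They also leave open how 3,5-dimethyl-1,2-oxazol-4-yl behaves with cyclopentyl on the amide, a pairing that would show whether the two places act independently.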